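This account rests on a few compounds, and the source may have more. Where it says the series, first, only, none or still open, it means among the compounds named here.

Of the compounds shown here, three that share one core have been tested in a functional assay on CHO cells for agonist activity at Free fatty acid receptor 1 (Homo sapiens), read by FLIPR and calcium flux; on this read-out higher numbers stand for an effect only at larger amounts of compound and lower numbers for an effect already at smaller amounts. Compound 2 `Cc1ccccc1-c1cccc(CNc2ccc(OCC(=O)O)c(F)c2)c1` gives 4.8 nM in this assay. Compound 3 `COCCOc1ccc(-c2cccc(CNc3ccc(OCC(=O)O)c(F)c3)c2)c(C)c1` carries a 2-methoxyethoxy in place of hydrogen on an aromatic carbon, and in this assay compound 3 gives 41.9 nM; the step of an 8.7-fold higher number from compound 2 to compound 3 (0.94 log units; beyond the scatter) lies beyond the scatter. Compound 1 `Cc1cc(OCCCS(C)(=O)=O)cc(C)c1-c1cccc(CNc2ccc(OCC(=O)O)c(F)c2)c1` gives 59.8 nM in this assay. Compound 3 thus holds the second highest of the three numbers: its gap to compound 1 is within the scatter, while its gap to compound 2 is beyond it.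

Compound 4 `Cc1cc(OCCCS(C)(=O)=O)ccc1-c1cccc(CNc2ccc(OCC(=O)O)c(F)c2)c1` has not yet been measured. Compared with compound 3, the change is (methylsulfonyl)methyl in place of methoxy on a saturated chain carbon, two bonds along the chain from an oxygen on an aromatic ring. Among the compounds with values here, no measured step covers exactly this exchange. The closest guide is compound 1, which also carries a 3-(methylsulfonyl)propoxy chain and in this assay compound 1 gives 59.8 nM, a number that sits within the scatter of compound 3. From that, a step no larger than the scatter is expected, a 1.1-fold higher number from compound 3 to compound 4 (0.03 log units; within the scatter). Compound 4 is therefore estimated at 45 nM in this assay, with a range from 15 nM to 135 nM.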

Compound 4, half-maximal effective concentration in the Free fatty acid receptor 1 assay: 45.6 nM
Compound 4: the middle estimate sits 1.0-fold (0.01 log units) below what was measured; the range from low to high includes it.
By their numbers in the Free fatty acid receptor 1 assay, from the lowest: compound 2; then compounds 3, 4 and 1 (each within the scatter of the next).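

In the Free fatty acid receptor 1 assay, the exchange at this position gives a 1.1-fold higher number from compound 3 to compound 4 (0.04 log units; within the scatter), and 3-(methylsulfonyl)propoxy in place of hydrogen gives a 9.5-fold higher number from compound 2 to compound 4 (0.98 log units; beyond the scatter), so this sulfone-bearing chain and 2-methoxyethoxy cannot be told apart on this read-out, and both stand beyond the scatter from the unsubstituted compound 2. Hydrogen in place of methyl on an aromatic carbon gives a 1.3-fold lower number from compound 1 to compound 4 (0.12 log units; within the scatter), so that methyl also makes no readable difference here. In a physicochemical assay for lipophilicity, read by HPLC, in phosphate buffer, measured as octanol-water partition, at pH 7.4, tested at 100 uM (a lower number here means a more polar compound, a higher number a more lipophilic compound), however, compound 3 gives 2.23 and compound 4 gives 1.59 so the two chains do separate, with compound 4 the more polar of the pair: the measured distribution coefficient of compound 3, 2.23, and of compound 4, 1.59, a number 0.64 log units lower (beyond the scatter)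

Still open, on these data alone, is whether a chain ending in an amine or a carboxylic acid, or a longer chain, would keep the number near that of compound 3 or bring it back towards that of compound 2. The compounds shown also cannot tell what sets the shared step away from compound 2.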